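Notes on the aryl group on the ring nitrogen

The source may hold more compounds than are shown below. What is called first, only, known or untested is meant among the compounds shown, and "the series" means these compounds.

The series shares one core; compound 1 `COc1cc2c(Oc3ccc(NC(=O)c4nn(-c5ccccc5)c(=O)cc4C)cc3F)ccnc2cc1OCCCN1CCN(C)CC1` carries a phenyl on the aromatic nitrogen and compound 2 `COc1ccc(-n2nc(C(=O)Nc3ccc(Oc4ccnc5cc(OCCCN6CCN(C)CC6)c(OC)cc45)c(F)c3)c(C)cc2=O)cc1` a 4-methoxyphenyl in its place. In a functional assay on NCI-H460 cells (Homo sapiens) for inhibition, read by MTT assay, with a stated time of 72 h (on this read-out higher numbers stand for weaker inhibition and lower numbers for stronger inhibition), compound 1 gives 360 nM and compound 2 gives 3660 nM. Within the data shown here, the single measured step, a 10-fold higher number from compound 1 to compound 2 (1.01 log units; beyond the scatter), is the only comparison available. Compound 2 therefore stands with the highest number of the two, separated from compound 1 by that step.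

Compound 3 `COc1cc2c(Oc3ccc(NC(=O)c4nn(-c5ccc(F)c(F)c5)c(=O)cc4C)cc3F)ccnc2cc1OCCCN1CCN(C)CC1` differs from compound 2 by 3,4-difluorophenyl in place of 4-methoxyphenyl on an aromatic nitrogen; the 4-methoxyphenyl leaves and a 3,4-difluorophenyl enters at the same place. Among the measured compounds shown here, the one step that bears on this change is a 10-fold higher number from compound 1 to compound 2 (1.01 log units; beyond the scatter), which shows that the methoxy on that aryl ring went with a much higher number. Removing it is expected to move the number back toward that of compound 1, but whether the two fluorines add anything on top is not covered by any measured pair. The expected step is a 6.1-fold lower number from compound 2 to compound 3 (0.79 log units; beyond the scatter), a lower number beyond the scatter. Compound 3 is thus estimated at 600 nM in this assay, with a range from 200 nM to 2000 nM.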

Compound 3, half-maximal inhibitory concentration: 190 nM
Compound 3: middle estimate off by 3.2-fold (0.50 log units), on the high side; the measured number lies below the stated range.
By their numbers in this assay, from the lowest: compounds 3 and 1 (each within the scatter of the next); then compound 2.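

In this assay the change from 4-methoxyphenyl to 3,4-difluorophenyl on the aromatic nitrogen gives a 19-fold lower number from compound 2 to compound 3 (1.28 log units; beyond the scatter) and so shows that a substituted aryl ring at this position need not carry the high number of compound 2. The comparison with the plain phenyl gives a 1.9-fold lower number from compound 1 to compound 3 (0.28 log units; within the scatter) and places the 3,4-difluorophenyl level with the phenyl on this read-out, so that among these three compounds only the 4-methoxyphenyl stands apart. No measurement to hand accounts for the wide gap between the 4-methoxyphenyl and the 3,4-difluorophenyl at this position.

From the compounds shown here alone, what remains open is whether the high number of compound 2 goes with the methoxy group as such or would also appear with other groups on this ring, such as an amine, a carboxylic acid or a longer alkoxy chain. Going by these compounds, it is equally open whether a single fluorine would behave like the pair, and whether an aryl ring is needed at all, as a cyclohexyl group on the same nitrogen would test.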